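Adding a Second Chloro Group: From Compound 2 to Compound 3

The compounds below may be only part of what the source reports. "The series", "measured", "known", "first", "only" and "open" are said of these compounds alone.

Compound 1 `O=C(/C=C\c1ccccc1F)N1N=C(c2ccncc2)OC1c1c[nH]c2ccccc12` and compound 2 `O=C(/C=C\c1cccc(Cl)c1)N1N=C(c2ccncc2)OC1c1c[nH]c2ccccc12` share one core and differ only in the aryl group on the double-bonded chain. In an ADME assay on A549 cells (Homo sapiens) for cytotoxicity, read by MTT assay, with a stated time of 48 h (on this read-out lower numbers stand for stronger inhibition of growth and higher numbers for weaker inhibition of growth), compound 1 gives only a limit of > 30 ug/mL. In this assay compound 2 likewise gives only a limit of > 30 ug/mL. The step that the two limits leave unreadable from compound 1 to compound 2 is therefore unreadable because both values sit at the limit of > 30 ug/mL in this assay, at which 2 of the 2 values shown sit. Compound 2 thus stands at the limit of this assay, without a number of its own.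

Compound 3 `O=C(/C=C\c1cccc(Cl)c1Cl)N1N=C(c2ccncc2)OC1c1c[nH]c2ccccc12` differs from compound 2 by chloro in place of hydrogen on an aromatic carbon. Among the compounds with values here, the only measured step that touches the same ring is the one from compound 1 to compound 2, and it offers no readable size. Within the data shown here, no step here shows that a change on this ring moves the read-out in this assay beyond the scatter, so compound 3 is expected to stay near the limit, with an expected step that the limit leaves unreadable from compound 2 to compound 3. Compound 3 is therefore estimated at 35 ug/mL in this assay, within a range from 15 ug/mL to 80 ug/mL.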

Compound 3, concentration for 50% growth inhibition: > 30 ug/mL
Compound 3: no number, only a limit; the forecaster's own chance of this, stated with the estimate: 70%; the middle value is on the limit's open side.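

In this assay compound 3 gives only the limit > 30 ug/mL and so no new step can be read among compound 1, compound 2 and compound 3: the limit of > 30 ug/mL in this assay, at which 3 of the 3 values shown sit.

The compounds shown leave open how strongly any of the three inhibits growth and whether changing the aryl group on the chain moves the read-out at all.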